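The compounds below may be only part of what the source reports. "The series", "measured", "known", "first", "only" and "open" are said of these compounds alone.

Compound 1 `Cc1cc(Nc2cc(-c3ccccc3)[nH]n2)n2ncnc2n1` gives > 50000 nM in a functional assay on PC-9 cells (Homo sapiens) for inhibition, read by MTT assay, with a stated time of 72 h; on this read-out higher numbers stand for weaker inhibition and lower numbers for stronger inhibition.
Compound 2 `Cc1cc(Nc2cc(-c3ccccc3)[nH]n2)n2nc(SCc3ccc(F)cc3)nc2n1` gives 8110 nM.
Compound 3 `Cc1cc(Nc2cc(-c3ccccc3)[nH]n2)n2nc(SCc3ccccc3Br)nc2n1` gives 5630 nM.

Where compound 3 stands: its number and that of compound 2 differ only by a 1.4-fold lower number from compound 2 to compound 3 (0.16 log units; within the scatter), which is within the usual scatter, so the two are not told apart. For compound 1 this assay reports only a limit, (the limit of > 50000 nM in this assay, at which 1 of the 3 values shown sits).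

Compound 4 `C#CCSc1nc2nc(C)cc(Nc3cc(-c4ccccc4)[nH]n3)n2n1` differs from compound 3 by ethynyl in place of 2-bromophenyl on a saturated chain carbon bound to a sulfur. The measured steps that bear on this are an at least 6.1-fold lower number from compound 1 to compound 2 (0.78 log units; beyond the scatter) and an at least 8.8-fold lower number from compound 1 to compound 3 (0.94 log units; beyond the scatter), in which a (4-fluorobenzyl)sulfanyl or (2-bromobenzyl)sulfanyl group replaced hydrogen on an aromatic carbon. Compound 4 keeps a sulfur-linked group but a far smaller one, ethynyl in place of 2-bromophenyl, so a higher number is expected, a 2.8-fold higher number from compound 3 to compound 4 (0.45 log units; beyond the scatter), though only modestly. Compound 4 is therefore estimated at 16000 nM, between 5000 nM and 45000 nM.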

Compound 4, half-maximal inhibitory concentration: > 50000 nM
Compound 4: a limit, no number; the forecaster's own chance of this, stated with the estimate: 15%; middle value at least 3.1-fold (0.49 log units) away from the limit.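

Keeping a sulfur-linked group at this position is not enough on its own: in this assay there is an at least 8.8-fold higher number from compound 3 to compound 4 (0.94 log units; beyond the scatter), and an at least 6.1-fold higher number from compound 2 to compound 4 (0.78 log units; beyond the scatter). Among these compounds, the lower numbers go with the two benzyl groups on sulfur, which carry an aromatic ring, and not with propargyl, which has none. The step from compound 1 to compound 4 cannot be read, since both sit at the same limit: the limit of > 50000 nM in this assay, at which 2 of the 4 values shown sit.

Going by these compounds, whether the ring itself matters, or only the number of atoms in the group, stays open. A plain butyl chain or an unsubstituted benzyl on the sulfur would help to separate these.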